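Chain extension on the shared core

The compounds below may be only part of what the source reports. "The series", "measured", "known", "first", "only" and "open" are said of these compounds alone.

In a functional assay for antagonist activity at Adrenergic receptor alpha-1 (Rattus norvegicus) (a higher number here means weaker binding, a lower number tighter binding), compound 2 `O=c1cc(-c2ccc(Cl)cc2)oc2cc(OCCBr)ccc12` gives 119 nM, and compound 1 `O=c1cc(-c2ccccc2)oc2cc(OCCBr)ccc12` gives 127 nM, the two values within the scatter of each other; the step of a 1.1-fold lower number from compound 1 to compound 2 (0.03 log units; within the scatter) changes nothing of note. Compound 3 `O=c1cc(-c2ccc(Cl)cc2)oc2cc(OCCCCBr)ccc12` has not been measured; it differs from compound 2 by 2-bromoethyl in place of bromo on a saturated chain carbon, two bonds along the chain from an oxygen on an aromatic ring. For the measured compounds named here, no measured step touches this part of the molecule, as the single known step concerns a different position, so nothing beyond the scatter is expected in this assay in either direction. For compound 3 the estimate is 110 nM, range 40 nM to 320 nM, meaning an expected 1.1-fold lower number from compound 2 to compound 3 (0.03 log units; within the scatter).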

Compound 3, dissociation constant: 429 nM
Compound 3: middle estimate off by 3.9-fold (0.59 log units), on the low side, and the stated range ends below it.
By their numbers in this assay, from the lowest: compounds 2 and 1 (each within the scatter of the next); then compound 3.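

The chain on the oxygen is sensitive where the chloro position was not: 2-bromoethoxy to 4-bromobutoxy gives a 3.6-fold higher number from compound 2 to compound 3 (0.56 log units; beyond the scatter) in this assay, while the chloro change gave only a 1.1-fold lower number from compound 1 to compound 2 (0.03 log units; within the scatter). This single pair therefore shows weaker binding with the longer chain. No available evidence bears on the reason for this shift.

Open, on these data alone, is whether a 3-bromopropoxy chain or a chain longer than 4-bromobutoxy would follow the same direction. Also open, as far as these compounds go, is how an amine in place of the bromo would read.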